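This account rests on a few compounds, and the source may have more. Where it says the series, first, only, none or still open, it means among the compounds named here.

Among the compounds with values here, in a functional assay on HCT-116 cells (Homo sapiens), read by MTT assay, with a stated time of 72 h (a lower number here means a stronger inhibitor, a higher number a weaker inhibitor), compound 3 `Cc1ncnc2c1c(-c1ccsc1)cn2[C@@H]1O[C@H](CO)[C@@H](O)[C@H]1O` gives 1430 nM, the only true number among the three compounds measured so far. Compound 1 `CN(C)c1ncnc2c1c(-c1cc3ccccc3o1)cn2[C@@H]1O[C@H](CO)[C@@H](O)[C@H]1O` reads > 20000 nM, which is a limit of the assay and not a number. Compound 2 `Cc1ncnc2c1c(-c1cccs1)cn2[C@@H]1O[C@H](CO)[C@@H](O)[C@H]1O` reads > 20000 nM, which is also a limit.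

Compound 4 `Cc1ncnc2c1c(-c1cc3ccccc3o1)cn2[C@@H]1O[C@H](CO)[C@@H](O)[C@H]1O` differs from compound 3 in one place: 1-benzofuran-2-yl in place of thiophen-3-yl on an aromatic carbon. In short, 1-benzofuran-2-yl stands in place of thiophen-3-yl on an aromatic carbon of the shared core.

Within the data shown here, only one measured step bears directly on this site. It is an at least 13-fold lower number from compound 2 to compound 3 (1.14 log units; beyond the scatter), so exchanging one group for a closely related one here can change the result sharply. That makes the activity of compound 3 look sensitive to the group at this site, and thiophen-3-yl is the very group that compound 4 gives up. Compound 1 carries the same 1-benzofuran-2-yl group and reads > 20000 nM, although its core is not identical, so it is only a cautious hint.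

A move towards a higher number, meaning a weaker inhibitor, is therefore expected, and the estimated change is an 8.4-fold higher number from compound 3 to compound 4 (0.92 log units; beyond the scatter). Compound 4 may well report only a limit too, a real possibility given (the limit of > 20000 nM in this assay, at which 2 of the 3 values shown sit). For compound 4 the estimated value is 12000 nM, with an expected range from 2500 nM to 40000 nM.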

Compound 4, half-maximal inhibitory concentration: > 20000 nM
Compound 4 ended at the assay's limit (the forecaster's own chance of this, stated with the estimate: 60%); middle value at least 1.6-fold (0.22 log units) from the limit.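

In this assay, 1-benzofuran-2-yl in place of thiophen-3-yl on the shared core gives an at least 13-fold higher number from compound 3 to compound 4 (1.14 log units; beyond the scatter), so a group seen before only on the core of compound 1 now fails, in a direct comparison that differs in one place, to keep the activity of compound 3. Compound 4 reads > 20000 nM, which is a limit of the assay and not a number. Thiophen-3-yl therefore remains the only group at this site with a true measured value among the compounds shown, while the steps joining compound 4 to compound 1 and to compound 2 link two limits and cannot be read.

A phenyl, furan-3-yl or pyridin-3-yl group at this place could show whether activity here belongs to thiophen-3-yl alone or extends to other single aromatic rings. How much weaker compound 4 truly is than the limit suggests, and how it ranks against compound 1 and compound 2, stays open: the limit of > 20000 nM in this assay, at which 3 of the 4 values shown sit.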